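This account rests on a few compounds, and the source may have more. Where it says the series, first, only, none or still open, it means among the compounds named here.

Of the compounds shown here, two measured so far set the scene. In a functional assay with platelet-activating factor receptor (Cavia porcellus) as the target (a lower number here means that less compound is needed, a higher number that more compound is needed for the effect), compound 1 `COc1ccc(/C(=C/C=C/C(=O)N[C@H](C)CCCc2cccnc2)C2CCCCC2)cc1` gives 0.21 mg/kg. Compound 2 `COc1cccc(C(=C/C=C/C(=O)N[C@H](C)CCCc2cccnc2)c2cccc(OC)c2)c1` differs from compound 1 elsewhere in the molecule, and in this assay compound 2 gives 0.21 mg/kg. On these numbers compound 2 stands level with compound 1 at the digits shown; the two values lie within the usual scatter of each other, so no order can be read between them, and no single-point step between them is recorded.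

Compound 3 `COc1cccc(C(=C/C=C/C(=O)NCCCCc2cccnc2)c2cccc(OC)c2)c1` has not yet been measured. It differs from compound 2 in one place: hydrogen in place of methyl on a saturated chain carbon bound to an amide-type nitrogen and a saturated chain carbon. Among the measured compounds shown here, no measured pair shows this particular change, so its effect is unknown from the data at hand. For the measured compounds named here, the measured compounds show only that a change elsewhere left the dose unchanged within the scatter. Removal of a small group near the amide nitrogen is expected to shift the dose only modestly, if at all, and the expected step of a 1.4-fold higher number from compound 2 to compound 3 (0.15 log units; within the scatter) is small and toward a slightly higher dose. For compound 3 the estimated dose in this assay is 0.3 mg/kg, with a range from 0.1 mg/kg to 1 mg/kg.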

Compound 3, dose for 50% inhibition: 0.36 mg/kg
Compound 3: the middle estimate sits 1.2-fold (0.08 log units) below what was measured; measured number inside the range.
By their numbers in this assay, from the lowest: compounds 1, 2 and 3 (each within the scatter of the next).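

Among the compounds shown here, this is the first single-point step, and it isolates the methyl on the saturated chain carbon bound to the amide-type nitrogen: replacing it with hydrogen, which turns 1-methyl-4-(pyridin-3-yl)butyl into 4-(pyridin-3-yl)butyl, gives a 1.7-fold higher number from compound 2 to compound 3 (0.23 log units; within the scatter) in this assay. The two doses therefore cannot be put in order, and for this pair the methyl, with the defined spatial arrangement at its carbon, is not required for a dose in the same range as compound 2. No accompanying measurement bears on how this side chain acts or on what the methyl contributes.

The compounds shown leave open how a larger group at this carbon, such as ethyl, or a hydroxyl group or an amine would compare, since methyl and hydrogen are the only two substituents seen here. They also leave open whether the same swap would give a similarly small step on the core of compound 1, or whether the mirror-image arrangement of the methyl would match compound 2.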